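The compounds below may be only part of what the source reports. "The series", "measured", "known", "first", "only" and "open" are said of these compounds alone.

Compound 1 `Cc1ccccc1-n1cc(CN2C(=O)C[C@@H]3CC[C@@]2(C)C3(C)C)nn1` gives 90 nM in a functional assay on A549 cells (Homo sapiens) for inhibition, read by MTT assay, with a stated time of 24 h; a higher number here means a weaker inhibitor, a lower number a stronger inhibitor.
Compound 2 `CC1(C)[C@H]2CC[C@]1(C)N(Cc1cn(-c3ccccc3)nn1)C(=O)C2` gives 70 nM in this assay.
Compound 3 `CC1(C)[C@H]2CC[C@]1(C)N(Cc1cn(-c3ccccc3C#N)nn1)C(=O)C2` gives 100 nM in this assay.

Compound 3 has the highest of the three numbers, yet all three sit within the scatter of one another: the change was a 1.1-fold higher number from compound 1 to compound 3 (0.05 log units; within the scatter) and a 1.4-fold higher number from compound 2 to compound 3 (0.15 log units; within the scatter). Compound 4 `CC1(C)[C@H]2CC[C@]1(C)N(Cc1cn(-c3ccc(F)cc3)nn1)C(=O)C2` differs from compound 3 in one place: 4-fluorophenyl in place of 2-cyanophenyl on an aromatic nitrogen. The two steps already seen on this group, cyano replacing methyl and cyano replacing hydrogen, both stayed within the scatter, so swapping the cyanophenyl for a fluorophenyl is expected to give a 1.2-fold lower number from compound 3 to compound 4 (0.07 log units; within the scatter), with no shift beyond the scatter. Compound 4 is therefore estimated at 85 nM, with a likely range from 40 nM to 180 nM.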

Compound 4, half-maximal inhibitory concentration: 230 nM
The estimate for compound 4 lay 2.7-fold (0.43 log units) below the measured number; the whole stated range lies below it.
By their numbers in this assay, from the lowest: compounds 2, 1 and 3 (each within the scatter of the next); then compound 4.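

In this assay, the group on the aromatic nitrogen proves sensitive to change: adding one fluoro to the plain phenyl gives a 3.3-fold higher number from compound 2 to compound 4 (0.52 log units; beyond the scatter). The 4-fluorophenyl also gives a 2.6-fold higher number from compound 1 to compound 4 (0.41 log units; beyond the scatter) and a 2.3-fold higher number from compound 3 to compound 4 (0.36 log units; beyond the scatter), whereas the 2-methylphenyl and 2-cyanophenyl stayed within the scatter of the plain phenyl. Nothing available explains this rise.

Whether the shift follows from the fluoro itself or from its place on the ring remains open, since 2-fluorophenyl and 4-cyanophenyl are not among the compounds shown. On these data alone, how an amine or a carboxylic acid on this phenyl ring would behave also remains open.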